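The source may report more compounds than this note shows. Statements on the series, on what has been measured and on what is new or still open speak of the compounds shown alone.

Compound 1 `O=C(O)CC/C=C\CC1COC(c2ccc([N+](=O)[O-])cc2)OC1c1cccnc1` gives 39 nM in an assay for inhibition of Thromboxane-A synthase (Homo sapiens), using microsomes; a lower number here means a stronger inhibitor, a higher number a weaker inhibitor. Compound 2 `O=C(O)CC/C=C\CC1COC(c2cccs2)OC1c1cccnc1` gives 71 nM in this assay; the step of a 1.8-fold higher number from compound 1 to compound 2 (0.26 log units; within the scatter) stays within the scatter, so these two numbers cannot be placed in any order. Compound 3 `CC(C)(C)c1ccc(OC(C)(C)C2OCC(C/C=C\CCC(=O)O)C(c3cccnc3)O2)cc1` gives 280 nM in this assay, the highest of the three numbers, and it lies beyond the scatter above both compound 2, its nearest neighbour, and compound 1, its furthest.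

Compound 4 `CSc1ccccc1OC(C)(C)C1OCC(C/C=C\CCC(=O)O)C(c2cccnc2)O1` differs from compound 3 in one place: 2-(methylsulfanyl)phenyl in place of 4-(tert-butyl)phenyl on an oxygen on a saturated carbon. Within the data shown here, none of the measured steps changes the group on this oxygen. Among the measured compounds shown here, the only measured step, a 1.8-fold higher number from compound 1 to compound 2 (0.26 log units; within the scatter), swaps an aromatic group on a saturated ring carbon, a different part of the shared core, and stays within the scatter. That gives a weak hint that swapping one aromatic group for another on this core moves the number little, but it bears on compound 4 only loosely, and a change of this kind at the oxygen could fall to either side. The step of a 1.1-fold lower number from compound 3 to compound 4 (0.05 log units; within the scatter) is therefore expected to be small. Compound 4 is estimated to give about 250 nM in this assay, with a range from 70 nM to 900 nM.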

Compound 4, half-maximal inhibitory concentration: 36 nM
Estimate against measurement, compound 4: 6.9-fold (0.84 log units) above; measured number outside the range, below it.
By their numbers in this assay, from the lowest: compounds 4, 1 and 2 (each within the scatter of the next); then compound 3.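

The group on this oxygen matters to the number: in this assay the change gives a 7.8-fold lower number from compound 3 to compound 4 (0.89 log units; beyond the scatter), a step beyond the scatter, although both groups contain one six-membered aromatic ring of carbon only. This single step changes several things at once, going from 10 heavy atoms to 8, adding a sulfur and one hydrogen-bond acceptor, and placing the substituent differently on the ring, so it cannot show which of these differences counts. No measurement shown here explains the size of this step.

The compounds shown leave open whether the methylsulfanyl group itself or its place on the ring carries the step, a question that a plain phenyl or a 4-(methylsulfanyl)phenyl on this oxygen could begin to separate. They also leave open whether the sulfur is needed, which a 2-methoxyphenyl at the same place could test against compound 4 in a single change.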